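Swapping a primary amine for piperidine on the ether chain

The source may report more compounds than this note shows. Statements on the series, on what has been measured and on what is new or still open speak of the compounds shown alone.

Compound 1 `O=C(Nc1cc(F)cc2cccnc12)c1ncccn1`: 300 nM
Compound 2 `COc1cc(NC(=O)c2ncccn2)c2ncccc2c1`: 1300 nM
Compound 3 `NCCOc1cc(NC(=O)c2ncccn2)c2ncccc2c1`: > 10000 nM

In a functional assay on MIA PaCa-2 cells (Homo sapiens) for inhibition, read by MTT assay, with a stated time of 72 h (on this read-out higher numbers stand for weaker inhibition and lower numbers for stronger inhibition), compound 1 gives 300 nM and compound 2 gives 1300 nM. For compound 3 only a limit is reported, > 10000 nM, so it is the weakest of the three. Compound 4 `O=C(Nc1cc(OCCC2CCNCC2)cc2cccnc12)c1ncccn1` differs from it by piperidin-4-yl in place of amino on a saturated chain carbon, two bonds along the chain from an oxygen on an aromatic ring. Among the compounds with values here, no measured step involves a piperidine; the steps that bear on this position are an at least 33-fold higher number from compound 1 to compound 3 (1.52 log units; beyond the scatter) and an at least 7.6-fold higher number from compound 2 to compound 3 (0.88 log units; beyond the scatter), both ending at the limit, where the limit of > 10000 nM in this assay, at which 1 of the 3 values shown sits, sits. Because compound 3 stands at > 10000 nM, a further loss would not be visible, and no shown step supports a gain. The expectation is therefore a step that the limit leaves unreadable from compound 3 to compound 4, no change beyond the scatter. Compound 4 is expected to give about 12000 nM, between 3000 nM and 50000 nM.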

Compound 4, half-maximal inhibitory concentration: > 10000 nM
Compound 4 was reported as a limit (the forecaster's own chance of this, stated with the estimate: 55%); the middle value does not contradict the limit.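

In this assay compound 4 is reported only as a limit, > 10000 nM. The piperidine ring therefore brings no activity back into the readable range: the 2-(piperidin-4-yl)ethoxy group gives an at least 33-fold higher number from compound 1 to compound 4 (1.52 log units; beyond the scatter), and in the methoxy series it gives an at least 7.6-fold higher number from compound 2 to compound 4 (0.88 log units; beyond the scatter). The step between compound 3 and compound 4 cannot be read, because both compounds sit at the limit: the limit of > 10000 nM in this assay, at which 2 of the 4 values shown sit.

As far as these compounds go, how far either compound lies beyond that limit stays open. So does whether a 2-hydroxyethoxy chain or a morpholine at the chain end would return to a readable value.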